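From Methylsulfanyl to Methylsulfonyl: One Change, One Estimate

The source may hold more compounds than are shown below. What is called first, only, known or untested is meant among the compounds shown, and "the series" means these compounds.

Measured compounds:
compound 1 `CS(=O)(=O)c1ccc(F)cc1NCC1=NCCN1`: < 100000 nM
compound 2 `CSc1ccc(C(F)(F)F)cc1NCC1=NCCN1`: 43.7 nM

Among the compounds with values here, in a functional assay for agonist activity at Alpha-1D adrenergic receptor (Homo sapiens) (on this read-out higher numbers stand for an effect only at larger amounts of compound and lower numbers for an effect already at smaller amounts), compound 2 gives 43.7 nM, the only number among the two results. Compound 1 reports only a limit, < 100000 nM, in this assay (the limit of < 100000 nM in this assay, at which 1 of the 2 values shown sits). Compound 3 `CS(=O)(=O)c1ccc(C(F)(F)F)cc1NCC1=NCCN1` differs from compound 2 by methylsulfonyl in place of methylsulfanyl on an aromatic carbon. Within the data shown here, no measured pair shows this change, so the step cannot be read from the two values. A weakening beyond the scatter is expected, estimated as a 23-fold higher number from compound 2 to compound 3 (1.36 log units; beyond the scatter). Compound 3 is expected to give 1000 nM, with a likely range from 100 nM to 20000 nM.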

Compound 3, half-maximal effective concentration: < 100000 nM
Compound 3 gave a limit, no number; the forecaster's own chance of this, stated with the estimate: 30%; the middle value is on the limit's open side.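

Within the data shown here, compound 3 reports only a limit in this assay and neither the step from compound 2 to compound 3 nor the one from compound 1 to compound 3 can be read. The compounds shown leave open how large the effect of methylsulfonyl in place of methylsulfanyl is, and whether trifluoromethyl in place of fluoro has any effect.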